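The compounds below may be only part of what the source reports. "The series", "measured", "known", "first", "only" and "open" are said of these compounds alone.

- Compound 1 `Cc1ccc(Nc2nccc(-c3ccnc4ccccc34)n2)cc1`: 1400 nM
- Compound 2 `FC(F)(F)c1ccc(Nc2nccc(-c3cnc4ccccc4c3)n2)cc1`: "not determined" (no result reported)

Going by the values given here, in a functional assay on SK-LU-1 cells (Homo sapiens) for cytotoxicity, read by sulforhodamine B assay, with a stated time of 48 h (on this read-out lower numbers stand for stronger inhibition and higher numbers for weaker inhibition), compound 1 gives 1400 nM, the only number available, as compound 2 has no result. Compound 3 `Nc1nccc(-c2ccnc3ccccc23)n1` has yet to be measured. Its structure differs from that of compound 1 by hydrogen in place of 4-methylphenyl on a nitrogen on an aromatic ring, with hydrogen in place of 4-methylphenyl on a nitrogen on an aromatic ring. Among the compounds with values here, no measured step guides this change, so the expectation rests on compound 1 at 1400 nM alone, and a moderate move toward weaker inhibition in this assay is anticipated. The expected step is a 4.3-fold higher number from compound 1 to compound 3 (0.63 log units; beyond the scatter). The estimate for compound 3 is 6000 nM, with an expected range from 1500 nM to 30000 nM.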

Compound 3, half-maximal inhibitory concentration: > 50000 nM
Compound 3 gave a limit, no number; the forecaster's own chance of this, stated with the estimate: 25%; middle value at least 8.3-fold (0.92 log units) away from the limit.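

Compound 3 gives only a limit in this assay, not a number. Even so, the change from (4-methylphenyl)amino to amino is a large loss (an at least 35-fold higher number from compound 1 to compound 3 (1.55 log units; beyond the scatter)), the first step read at this place. The inhibition seen with compound 1 therefore requires more than the shared core with a bare amino group: something on this nitrogen counts, and the 4-methylphenyl serves there. From the compounds shown here alone, whether a small methyl or a non-aromatic cyclohexyl on this nitrogen would keep that inhibition stays open, as does what the methyl on the phenyl ring contributes.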